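This account rests on a few compounds, and the source may have more. Where it says the series, first, only, none or still open, it means among the compounds named here.

In a functional assay on MGC-803 cells (Homo sapiens) for inhibition, read by MTT assay, with a stated time of 48 h (a higher number here means a weaker inhibitor, a lower number a stronger inhibitor), compound 2 `CCC/C=C/C(=O)N(Cc1ccc(OC)c(O)c1)c1cc(OC)c(OC)c(OC)c1` gives 70 nM, and compound 1 `COCC(=O)N(Cc1ccc(OC)c(O)c1)c1cc(OC)c(OC)c(OC)c1` gives 79 nM, so the two stand level. Compound 3 `COc1ccc(CN(C(=O)CN=[N+]=[N-])c2cc(OC)c(OC)c(OC)c2)cc1O` carries azidomethyl in place of pent-1-en-1-yl on a carbonyl carbon. For the measured compounds named here, only one measured step involves a change at this place: a 1.1-fold lower number from compound 1 to compound 2 (0.05 log units; within the scatter). Going by the values given here, that step stayed within the scatter, but a single step is thin evidence, and no azidomethyl compound has been measured yet. The expected size in this assay is therefore small, with no clear direction: a 1.1-fold higher number from compound 2 to compound 3 (0.06 log units; within the scatter). For compound 3 the estimate is 80 nM, with an expected range of 28 nM to 240 nM.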

Compound 3, half-maximal inhibitory concentration: 120 nM
Compound 3: middle estimate off by 1.5-fold (0.18 log units), on the low side; the measured number falls inside the stated range.
By their numbers in this assay, from the lowest: compounds 2, 1 and 3 (each within the scatter of the next).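

In this assay azidomethyl on the carbonyl carbon gives a 1.7-fold higher number from compound 2 to compound 3 (0.23 log units; within the scatter) and azido in place of methoxy on the saturated chain carbon gives a 1.5-fold higher number from compound 1 to compound 3 (0.18 log units; within the scatter). This place has now carried methoxymethyl, pent-1-en-1-yl and azidomethyl, the last with three nitrogens, and neither new step leaves the scatter. No measurement here bears on the reason for these small steps. As far as these compounds go, whether an amine, a carboxylic acid or a longer chain on this carbonyl carbon would move the number beyond the scatter stays open.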